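Chain substituents on an amide-bearing cyclopropane core: step to compound 4

The source may report more compounds than this note shows. Statements on the series, on what has been measured and on what is new or still open speak of the compounds shown alone.

Measured compounds:
Compound 1, `COCCN(C)C(=O)[C@@]1(c2ccsc2)C[C@H]1CN`, gives > 10000 nM in an assay on HEK293 cells for inhibition of sodium-dependent dopamine transporter (Homo sapiens); a higher number here means a weaker inhibitor, a lower number a stronger inhibitor.
Compound 2, `C#CCN(CCOC)C(=O)[C@@]1(c2ccsc2)C[C@H]1CN`, gives > 10000 nM in this assay.
Compound 3, `C=C(F)CN(C)C(=O)[C@@]1(c2ccsc2)C[C@H]1CN`, gives > 10000 nM in this assay.

Each of these values is a limit of the assay, not a number, and compound 3 stands at that limit along with the other two, as the limit of > 10000 nM in this assay, at which 3 of the 3 values shown sit, records. Compound 4, `C=C(F)CN(CCOC)C(=O)[C@@]1(c2ccsc2)C[C@H]1CN`, differs from compound 3 by methoxymethyl in place of hydrogen on a saturated chain carbon bound to an amide-type nitrogen. For the measured compounds named here, two measured steps touch the same place: a step that the two limits leave unreadable from compound 1 to compound 2 and a step that the two limits leave unreadable from compound 1 to compound 3, and both are unreadable because both ends sit at the limit. Going by the values given here, no step in this set gives a readable size, so compound 4 is expected to stay at the limit as well, a step that the limit leaves unreadable from compound 3 to compound 4. Compound 4 is therefore estimated at 20000 nM, between 5000 nM and 100000 nM.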

Compound 4, half-maximal inhibitory concentration: > 10000 nM
Compound 4: only a limit was reported; the forecaster's own chance of this, stated with the estimate: 85%; the middle value does not contradict the limit.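

In this assay compound 4 gives > 10000 nM, a limit of the assay and not a number, and its steps from compound 1, compound 2 and compound 3 cannot be read. The compounds shown leave open whether any of these chain substituents on the shared core changes the inhibition at all.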